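Changing the aryl group on the amine nitrogen of compound 1

The source may hold more compounds than are shown below. What is called first, only, known or untested is meant among the compounds shown, and "the series" means these compounds.

The measurements come from a functional assay on HeLa cells (Homo sapiens) for inhibition, read by sulforhodamine B assay; on this read-out lower numbers stand for stronger inhibition and higher numbers for weaker inhibition. For the measured compounds named here, compound 1 `Cc1ccc(NC2=CC(=O)c3nc4n(c3C2=O)[C@H]2OC[C@@H](O)[C@H]2OC4)cc1` is the only compound with a definite number: in this assay compound 1 gives 3860 nM. Compound 2 `COc1ccc(NC2=CC(=O)c3c(nc4n3[C@H]3OC[C@@H](O)[C@H]3OC4)C2=O)cc1`, which carries a 4-methoxyphenyl on the amine nitrogen, reaches only a limit, > 8000 nM, so its true value is not known. Compound 3 `O=C1C(NC2CCCCC2)=CC(=O)c2c1nc1n2[C@H]2OC[C@@H](O)[C@H]2OC1`, with a cyclohexyl on that nitrogen, also stops at a limit, > 16000 nM. Going by the values given here, the one step between compounds that differ in a single place, a step that the two limits leave unreadable from compound 2 to compound 3, therefore cannot be read in size.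

Compound 4 `CCOc1ccccc1NC1=CC(=O)c2nc3n(c2C1=O)[C@H]1OC[C@@H](O)[C@H]1OC3` differs from compound 1 by 2-ethoxyphenyl in place of 4-methylphenyl on an amine nitrogen. Among the compounds with values here, no measured step bears directly on this change. What can be said is that compound 1 has a number while compound 2, the other compound with an oxygen-bearing aryl group on the amine nitrogen, sits at the limit of > 8000 nM in this assay, at which 1 of the 3 values shown sits. On that thin ground a weakening step is expected from compound 1 to compound 4, of roughly a 2.1-fold higher number from compound 1 to compound 4 (0.32 log units; beyond the scatter). Compound 4 is therefore estimated to give about 8000 nM in this assay, somewhere between 3000 nM and 25000 nM, with a fair chance that only a limit is reported.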

Compound 4, half-maximal inhibitory concentration: 6040 nM
Compound 4: middle estimate off by 1.3-fold (0.12 log units), on the high side; measured number inside the range.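

In this assay, replacing the aryl group on the amine nitrogen gives a 1.6-fold higher number from compound 1 to compound 4 (0.19 log units; within the scatter), so 4-methylphenyl and 2-ethoxyphenyl cannot be told apart in this cell test. For the compounds shown here, this is the only step at this position that can be read in size, and it shows that an aryl group with more heavy atoms and one oxygen can sit on this nitrogen and still yield a definite number. Compound 2, which also carries an oxygen on its aryl group, remains a limit and not a number: the limit of > 8000 nM in this assay, at which 1 of the 4 values shown sits.

The two groups in this step differ in more than one respect, so it cannot say what each difference contributes, and the steps involving the limits still cannot be read. On these data alone, it also remains open how the number would respond to an unsubstituted phenyl, to a longer chain such as butoxy on the aryl ring, or to an aryl group carrying an amine or a carboxylic acid.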